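Exchanging Phenyl for 4-Chloropyridin-3-yl on the Amide Carbonyl

The compounds below may be only part of what the source reports. "The series", "measured", "known", "first", "only" and "open" are said of these compounds alone.

Of the compounds shown here, three sharing one core have been measured in a functional assay on HEK293 cells for agonist activity at D(4) dopamine receptor (Homo sapiens), read by FLIPR; on this read-out higher numbers stand for larger maximal responses and lower numbers for smaller maximal responses. Compound 1 `Cc1cc(C(=O)NCN2CCC(c3cccc[n+]3[O-])CC2)ccc1F` gives 67%. Compound 2 `O=C(NCN1CCC(c2cccc[n+]2[O-])CC1)c1ccccc1` gives 63%, the smallest of the three numbers shown; the step of a number 4 percentage points lower from compound 1 to compound 2 (within the scatter) lies within the scatter, so these two cannot be told apart. Compound 3 `Cc1cc(NC(=O)CN2CCC(c3cccc[n+]3[O-])CC2)ccc1F` gives 75%, and its gap to compound 2 lies beyond the scatter.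

Compound 4 `O=C(NCN1CCC(c2cccc[n+]2[O-])CC1)c1cnccc1Cl` has not yet been measured in this assay. It differs from compound 2 in one place: 4-chloropyridin-3-yl in place of phenyl on a carbonyl carbon. Within the data shown here, the only measured step that touches the same place, an exchange of one aromatic group for another on the carbonyl carbon, is a number 4 percentage points lower from compound 1 to compound 2 (within the scatter), and it stayed within the scatter. Among the measured compounds shown here, no measured step shows what a six-membered aromatic ring with 1 hetero atom does at this position, so nothing points to a change in either direction. The step from compound 2 to compound 4 is therefore expected to be small, a number 1 percentage points higher from compound 2 to compound 4 (within the scatter). Compound 4 is estimated at 64%, within a range from 50% to 78%.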

Compound 4, largest response reached (reported as efficacy), in percent of the reference or control that the assay uses: 44%
Compound 4: the middle estimate sits 20 percentage points above what was measured; measured number outside the range, below it.
By their numbers in this assay, from the lowest: compound 4; then compounds 2, 1 and 3 (each within the scatter of the next, the first and the last beyond it).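

In this assay, among these compounds, the aromatic group on the carbonyl carbon proves able to change the maximal response: 4-chloropyridin-3-yl in place of phenyl gives a number 19 percentage points lower from compound 2 to compound 4 (beyond the scatter) and, in place of 4-fluoro-3-methylphenyl, it gives a number 23 percentage points lower from compound 1 to compound 4 (beyond the scatter) while the only earlier exchange at this place stayed within the scatter. This place is therefore not indifferent to the group it carries, and both rings of carbon only give larger maximal responses here than the 4-chloropyridin-3-yl group. No measurement is available that would explain this difference.

The ring nitrogen and the chlorine enter together, and the compounds shown do not separate what each contributes. A pyridin-3-yl group without the chlorine and a 4-chlorophenyl group would each carry only one of the two.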